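Removing a Methoxy Group from a Pyridyl Bicyclic Amine Series

The source may hold more compounds than are shown below. What is called first, only, known or untested is meant among the compounds shown, and "the series" means these compounds.

Measured so far:
compound 1 `C1=C(c2cncc(Oc3ccccc3)c2)CC2CNCC1C2`, 0.7 nM
compound 2 `COc1ccc(Oc2cncc(C3=CC4CNCC(C3)C4)c2)cc1`, 1.4 nM
compound 3 `COc1cncc(C2=CC3CNCC(C2)C3)c1`, 0.3 nM

In an in vitro assay on SH-EP1 cells for displacement of a labelled ligand from Neuronal acetylcholine receptor; alpha4/beta2 (Homo sapiens) (on this read-out higher numbers stand for weaker inhibition and lower numbers for stronger inhibition), compound 3 gives the lowest of the three numbers. Compound 4 `C1=C(c2cccnc2)CC2CNCC1C2` is not yet measured. Compound 4 arises from compound 3 by hydrogen in place of methoxy on an aromatic carbon; the same kind of change links compound 2 to compound 1, (hydrogen in place of methoxy on an aromatic carbon), where it made a 2.0-fold lower number from compound 2 to compound 1 (0.30 log units; within the scatter). The two settings are not the same: in one case the place is on a six-membered aromatic ring of carbon only, para to a large group, in the other on a six-membered aromatic ring with 1 nitrogen, two atoms from the ring nitrogen, meta to a group of 9 heavy atoms. The cores also differ, by methyl in place of 4-methoxyphenyl on an oxygen on an aromatic ring. Resting on the small step seen for compound 2 to compound 1 a 2.0-fold lower number from compound 2 to compound 1 (0.30 log units; within the scatter), but allowing that a methoxy on the ring with nitrogen may matter more, compound 4 is expected to show a 3.3-fold higher number from compound 3 to compound 4 (0.52 log units; beyond the scatter), giving an estimated 1 nM, between 0.3 nM and 4 nM.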

Compound 4, inhibition constant: 0.2 nM
Estimate against measurement, compound 4: 5.0-fold (0.70 log units) above; measured number below the stated range.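

In this assay, hydrogen in place of methoxy gives a 1.5-fold lower number from compound 3 to compound 4 (0.18 log units; within the scatter), and this step agrees with the one on the other core: the same change on two cores in this assay, a 2.0-fold lower number (0.30 log units; within the scatter) from compound 2 to compound 1 and a 1.5-fold lower number (0.18 log units; within the scatter) from compound 3 to compound 4, 1.3-fold (0.12 log units) apart, within the scatter of two such steps. The change therefore carries over between these two cores, with neither step beyond the scatter, although it sits on a ring with nitrogen in one case and on a carbon-only ring in the other; this rests on two pairs only and sets no rule for other cores. Hydrogen in place of phenoxy is a different change, and it gives a 3.5-fold lower number from compound 1 to compound 4 (0.54 log units; beyond the scatter).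

The compounds shown leave open what an amine, a carboxylic acid or a longer chain on that aromatic carbon would give. They also leave open how these changes behave on any other read-out.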